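The source may report more compounds than this note shows. Statements on the series, on what has been measured and on what is new or still open speak of the compounds shown alone.

Compound 1 `CC/N=C(\N)Nc1ccc(Sc2ccc(OC)cc2)cc1` is the starting point of this account. For the measured compounds named here, in an assay (Rattus norvegicus) for binding affinity to prostacyclin receptor (Homo sapiens), read by radioligand binding (a lower number here means a stronger inhibitor, a higher number a weaker inhibitor), compound 1 gives 251 nM, the single number recorded for it, alongside one further entry that carries no number. Compound 2 `COc1ccc(Sc2ccc(NC3=NCCN3)cc2)cc1` is the other measured compound of the set; in this assay compound 2 gives 50.1 nM; 50.1 nM (2 entries), a value returned twice in agreement. Compound 3 `COc1ccc(Sc2ccc(NC3=NC(C)CN3)cc2)cc1` has not been measured. It arises from compound 1 by a group of 6 heavy atoms (4 carbon, 2 nitrogen; one five-membered non-aromatic ring with 2 hetero atoms) in place of a group of 5 heavy atoms (3 carbon, 2 nitrogen; no ring), on a nitrogen on an aromatic ring. Going by the values given here, no measured pair in the set reproduces this change, so its effect is unknown, and compound 2 offers only its own value as a point of comparison. The step from compound 1 to compound 3 is expected to be a gain beyond the scatter, a 3.6-fold lower number from compound 1 to compound 3 (0.55 log units; beyond the scatter), resting on compound 2's value of 50.1 nM; 50.1 nM (2 entries). Compound 3 is therefore estimated at 70 nM, within a range of 25 nM to 200 nM.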

Compound 3, inhibition constant: 63.1 nM
Compound 3: middle estimate off by 1.1-fold (0.05 log units), on the high side; the measured number falls inside the stated range.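

In this assay, the change on the nitrogen now has its first measured step: the group of 5 heavy atoms with no ring gives way to the one with a five-membered non-aromatic ring, and a 4.0-fold lower number from compound 1 to compound 3 (0.60 log units; beyond the scatter) is beyond the scatter. The gain holds with the methyl-bearing ring of compound 3, which gives 63.1 nM, while compound 2 gives 50.1 nM; 50.1 nM (2 entries), and these two values lie within the usual scatter of each other. No measurement shown here explains why the ring group gives the lower number.

On these data alone, whether a propyl chain on the open group would narrow the gap remains open. So does whether a phenyl group or a hydroxymethyl group on the five-membered ring would keep the number at this level.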